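Pyrazolo-fused series: aryl versus methyl at the ring carbon

The source may report more compounds than this note shows. Statements on the series, on what has been measured and on what is new or still open speak of the compounds shown alone.

Measured values in a functional assay on U-251 cells (Homo sapiens) for cytotoxicity, read by resazurin assay, with stated times of 30 s and 48 h; on this read-out higher numbers stand for weaker inhibition and lower numbers for stronger inhibition:
Compound 1, `COc1ccc(-c2cc(=O)n3nc(-c4ccccc4)cc3[nH]2)cc1`, gives 5670000 nM.
Compound 2, `Cc1cc2[nH]c(-c3ccccc3)cc(=O)n2n1`, gives 56800 nM.
Compound 3, `Cc1cc(C)cc(-c2cc(=O)n3nc(C(C)C)cc3[nH]2)c1`, gives 609000 nM.

Compound 2 stands at the lowest of the three numbers in this assay; compound 3 is the nearest to it and compound 1 the furthest, both gaps beyond the scatter. Within the data shown here, no single-point steps between measured compounds exist, so no measured step can be quoted.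

Compound 4, `Cc1ccc(-c2cc3[nH]c(-c4ccccc4)cc(=O)n3n2)cc1`, is not yet measured. It differs from compound 2 by 4-methylphenyl in place of methyl on an aromatic carbon. Among the measured compounds shown here, the only comparison at hand is compound 1, which also pairs a phenyl with a second aromatic ring of carbon only and gives 5670000 nM against compound 2 at 56800 nM. On that basis a weakening step is expected for compound 4, well beyond the scatter, though smaller than the full gap to compound 1 because compound 1 at 5670000 nM carries a methoxy group that compound 4 lacks. The step from compound 2 to compound 4 is estimated as an 18-fold higher number from compound 2 to compound 4 (1.25 log units; beyond the scatter). Compound 4 is expected at 1000000 nM, within 150000 nM to 6000000 nM.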

Compound 4, half-maximal inhibitory concentration: 86700 nM
Beside the measured number, compound 4's estimate is 12-fold (1.06 log units) above it; measured number below the stated range.
By their numbers in this assay, from the lowest: compounds 2 and 4 (each within the scatter of the next); then compound 3; then compound 1.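

On an aromatic carbon of the five-membered ring, next to the ring nitrogen, 4-methylphenyl in place of methyl gives a 1.5-fold higher number from compound 2 to compound 4 (0.18 log units; within the scatter) in this assay, a step within the scatter. Among these compounds, this is the first single-place comparison, and it shows that this position accepts a six-membered aromatic ring of carbon only in place of methyl with no change that can be read from this assay. No measurement at hand accounts for this result.

The compounds shown leave open whether an amine, a carboxylic acid or a longer chain at this position would also stay within the scatter of compound 2. Also open, going by these compounds, is whether the same holds when the phenyl shared by compound 2 and compound 4 is replaced by another group.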